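The source may report more compounds than this note shows. Statements on the series, on what has been measured and on what is new or still open speak of the compounds shown alone.

Working notes on the series. Compound 2 `Fc1ccc(N2CCN(Cn3nc(-c4ccc5c(c4)OCCO5)oc3=S)CC2)cc1` reads as a limit in a functional assay on HepG2 cells (Homo sapiens) for antiproliferative activity, read by MTT assay, with a stated time of 48 h (on this read-out lower numbers stand for stronger inhibition and higher numbers for weaker inhibition), giving > 50000 nM. Compound 1 `S=c1oc(-c2ccc3c(c2)OCCO3)nn1CN1CCN(c2ccc(Cl)cc2)CC1` likewise returns only a limit, > 50000 nM. Among the measured compounds shown here, compound 3 `S=c1oc(-c2ccc3c(c2)OCCO3)nn1CN1CCN(c2ccccn2)CC1` is the one member with a number, at 11400 nM. The move from compound 1 to compound 2, fluoro in place of chloro on an aromatic carbon, shows a step that the two limits leave unreadable from compound 1 to compound 2 because both sit at the limit of > 50000 nM in this assay, at which 2 of the 3 values shown sit. Pyridin-2-yl in place of 4-fluorophenyl gives an at least 4.3-fold lower number from compound 2 to compound 3 (0.64 log units; beyond the scatter), and pyridin-2-yl in place of 4-chlorophenyl gives an at least 4.3-fold lower number from compound 1 to compound 3 (0.64 log units; beyond the scatter).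

Compound 4 `S=c1oc(-c2ccc3c(c2)OCCO3)nn1CN1CCN(c2ccccc2)CC1` differs from compound 2 by hydrogen in place of fluoro on an aromatic carbon. For the measured compounds named here, no measured step removes a substituent from the aryl ring outright: the closest, the halogen exchange from compound 1 to compound 2, stays unreadable, and the steps to compound 3 replace the whole aryl group rather than one substituent. With both halogenated analogues at the limit, compound 4 is not expected to move beyond the scatter, its estimated step being a step that the limit leaves unreadable from compound 2 to compound 4. Compound 4 is therefore expected near 60000 nM in this assay, within 20000 nM to 200000 nM, most probably returned again only as a limit.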

Compound 4, half-maximal inhibitory concentration: > 50000 nM
Compound 4: a limit, no number (the forecaster's own chance of this, stated with the estimate: 70%); the middle value is on the limit's open side.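

In this assay compound 4, which carries a plain phenyl group, returns only a limit, > 50000 nM. Removing the halogen therefore does not bring the aryl series into readable range, and the gap to the pyridin-2-yl compound no longer rests on halogenated aryl groups alone: the change from pyridin-2-yl to phenyl gives an at least 4.3-fold higher number from compound 3 to compound 4 (0.64 log units; beyond the scatter). The steps among compounds 1, 2 and 4 cannot be read because all three sit at the same limit: the limit of > 50000 nM in this assay, at which 3 of the 4 values shown sit.

The compounds shown leave open how far compounds 1, 2 and 4 lie past that limit, so no order among the halogen and hydrogen forms can be drawn, and whether the ring nitrogen of the pyridin-2-yl group matters at that particular place, as pyridin-3-yl or pyridin-4-yl would test. Among the compounds shown here, also open is whether a methoxy or an amino group on the pyridin-2-yl ring would keep a readable number, given that compound 3 is the only member of the series with one.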